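From Methoxy to Trifluoromethoxy at the Limit of Measurement

This account rests on a few compounds, and the source may have more. Where it says the series, first, only, none or still open, it means among the compounds named here.

In a functional assay on KYSE-410 cells (Homo sapiens) for antiproliferative activity, read by MTT assay, with a stated time of 72 h (a higher number here means a weaker inhibitor, a lower number a stronger inhibitor), compound 1 `O=C(Nc1ccc(Cl)cc1)c1ccnc2cc(Br)ccc12` gives > 20000 nM as a limit and not a number. Compound 2 `COc1ccc(NC(=O)c2cc(=O)[nH]c3cc(Br)ccc23)cc1` gives > 20000 nM as a limit too. Compound 3 `O=C(Nc1ccc(F)cc1F)c1cc(=O)[nH]c2cc(Br)ccc12` gives > 20000 nM as a limit as well. Compound 2 thus sits with the others at the limit of > 20000 nM in this assay, at which 3 of the 3 values shown sit, and has no exact number. Compound 4 `O=C(Nc1ccc(OC(F)(F)F)cc1)c1cc(=O)[nH]c2cc(Br)ccc12` differs from compound 2 by trifluoromethyl in place of methyl on an oxygen on an aromatic ring. Among the measured compounds shown here, no measured step gives a size for this change, so in this assay nothing beyond the scatter is expected. The expected change is a number no higher from compound 2 to compound 4 (the limit leaves the size open) and no more. Compound 4 is estimated at 20000 nM with an expected range from 9000 nM to 40000 nM in this assay.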

Compound 4, half-maximal inhibitory concentration: > 20000 nM
Compound 4 was reported as a limit; the forecaster's own chance of this, stated with the estimate: 75%; the middle value sits exactly at the limit.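

Compound 2 and compound 4 are both reported as limits and not numbers, so no step can be read between them. The compounds shown leave open what methoxy to trifluoromethoxy does to potency, as all share one ceiling: the limit of > 20000 nM in this assay, at which 4 of the 4 values shown sit.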